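Does a non-aromatic carbon ring raise the number again?

The source may hold more compounds than are shown below. What is called first, only, known or untested is meant among the compounds shown, and "the series" means these compounds.

Within the data shown here, in a functional assay on NCI/ADR-RES cells (Homo sapiens) for inhibition, read by luminescence, with a stated time of 72 h (on this read-out higher numbers stand for weaker inhibition and lower numbers for stronger inhibition), compound 2 `Nc1ncnc2c1nc(Sc1cc3ccoc3cc1Br)n2CCC1CCN(C=O)CC1` gives 7900 nM here, the lower of the two numbers so far. Compound 1 `Nc1ncnc2c1nc(Sc1cc3c(cc1Br)OCC3)n2CCC1CCN(C=O)CC1` gives 86000 nM by comparison. Among the measured compounds shown here, compound 3 `Nc1ncnc2c1nc(Sc1cc3c(cc1Br)CCC3)n2CCC1CCN(C=O)CC1` carries 6-bromo-2,3-dihydro-1H-inden-5-yl in place of 6-bromo-1-benzofuran-5-yl on a sulfur as its one change: 6-bromo-2,3-dihydro-1H-inden-5-yl in place of 6-bromo-1-benzofuran-5-yl on a sulfur. For the measured compounds named here, the only measured step bearing on this is an 11-fold lower number from compound 1 to compound 2 (1.04 log units; beyond the scatter) in size, large and beyond the scatter, where the five-membered ring becomes aromatic. Compound 3 returns to a non-aromatic five-membered ring, but without oxygen. The expected change is a 3.2-fold higher number from compound 2 to compound 3 (0.50 log units; beyond the scatter) in this assay and so only part of that step reversed. The estimate for compound 3 is 25000 nM with a range from 6000 nM to 100000 nM expected.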

Compound 3, half-maximal inhibitory concentration: 230 nM
The estimate for compound 3 lay 110-fold (2.04 log units) above the measured number; the measured number lies below the stated range.
By their numbers in this assay, from the lowest: compound 3; then compound 2; then compound 1.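

In this assay, a non-aromatic ring does not by itself raise the number: a 34-fold lower number from compound 2 to compound 3 (1.54 log units; beyond the scatter) favours the all-carbon ring of 6-bromo-2,3-dihydro-1H-inden-5-yl on the sulfur over the aromatic 6-bromo-1-benzofuran-5-yl. Between the two non-aromatic rings, having carbon in place of the ring oxygen gives a 370-fold lower number from compound 1 to compound 3 (2.57 log units; beyond the scatter), the largest step so far. No supporting data explain either step. The compounds shown leave open whether a six-membered non-aromatic carbon ring would serve as well as the five-membered one. They also leave open what chlorine in place of the bromine would do.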